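Swapping methyl for chloro in a cytotoxicity series

The source may report more compounds than this note shows. Statements on the series, on what has been measured and on what is new or still open speak of the compounds shown alone.

Of the compounds shown here, three have been measured in a functional assay on MT4 cells (Homo sapiens) for cytotoxicity; a higher number here means a weaker inhibitor, a lower number a stronger inhibitor. Compound 1 `N#Cc1c(N)cccc1Sc1cc(Cl)cc(Cl)c1` gives 3000 nM in this assay. Compound 2 `Cc1cc(Cl)cc(Sc2cccc(N)c2C#N)c1` gives 16000 nM in this assay, and compound 3 `Cc1cccc(S(=O)(=O)c2cccc(N)c2C#N)c1` gives 179000 nM in this assay, the highest of the three numbers. Compound 2 and compound 1 differ in one place, (chloro in place of methyl on an aromatic carbon), and the measured step is a 5.3-fold lower number from compound 2 to compound 1 (0.73 log units; beyond the scatter). The difference between the core of compound 2 and the core of compound 3 is not broken down here.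

Compound 4 `N#Cc1c(N)cccc1S(=O)(=O)c1cccc(Cl)c1` has not yet been measured. It differs from compound 3 by the same kind of change, (chloro in place of methyl on an aromatic carbon). The surroundings are not identical: in compound 1 the chloro enters at a place that is also meta to a chloro group, while in compound 4 the place is only meta to a large group. The expectation for compound 4 rests on the earlier step of a 5.3-fold lower number from compound 2 to compound 1 (0.73 log units; beyond the scatter). The expected step for compound 4 is a 3.6-fold lower number from compound 3 to compound 4 (0.55 log units; beyond the scatter), set a little smaller than that earlier one. Compound 4 is therefore expected to give about 50000 nM in this assay, most likely between 20000 nM and 150000 nM.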

Compound 4, half-maximal inhibitory concentration: > 200000 nM
Compound 4: only a limit was reported; the forecaster's own chance of this, stated with the estimate: 10%; middle value at least 4.0-fold (0.60 log units) from the limit.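

In this assay compound 4 gives > 200000 nM, which is a limit of the assay and not a number. Even so, chloro in place of methyl gives an at least 1.1-fold higher number from compound 3 to compound 4 (0.04 log units; that floor lies within the scatter), so the lower number seen on the core of compound 2 did not carry over to the core of compound 3, and the two steps clearly differ: the same change on two cores in this assay, a 5.3-fold lower number (0.73 log units; beyond the scatter) from compound 2 to compound 1 and an at least 1.1-fold higher number (0.04 log units; that floor lies within the scatter) from compound 3 to compound 4, at least 5.9-fold (0.77 log units) apart, beyond the scatter of two such steps. This does not show the true size of the new step or why the two cores part, and compound 4 stays at the edge of what could be read: the limit of > 200000 nM in this assay, at which 1 of the 4 values shown sits.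

Still open, going by these compounds, is whether the split follows the sulfonyl link shared by compound 3 and compound 4 or the further chloro carried by compound 1 and compound 2. Also open, on these data alone, is how a sulfoxide link, or a fluoro or methoxy group in the place of the chloro, would read in this assay.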